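A Pyridine for a Pyrimidine on the Shared Core

The compounds below may be only part of what the source reports. "The series", "measured", "known", "first", "only" and "open" are said of these compounds alone.

Going by the values given here, compound 1 `FC(F)(F)c1cccc(-c2nc3cnc(Nc4ncccn4)cc3[nH]2)c1` and compound 2 `Fc1ccc(-c2nc3cnc(Nc4ccccn4)cc3[nH]2)cc1F` share a core and differ from each other in more than one place, so no single step is read from the pair. In a physicochemical assay for solubility, using the shake flask method, measured as kinetic solubility, with a stated time of 20 h, at pH 2 (a higher number here means a more soluble compound, a lower number a less soluble compound), compound 1 gives 155000 nM, the higher of the two numbers recorded. Compound 2 gives 125000 nM in this assay, a gap that lies within the usual scatter, so the two values cannot be told apart.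

Compound 3 `FC(F)(F)c1ccc(Nc2cc3[nH]c(-c4cccc(C(F)(F)F)c4)nc3cn2)nc1` is not yet measured in this assay and differs from compound 1 in a single place: 5-(trifluoromethyl)pyridin-2-yl in place of pyrimidin-2-yl on a nitrogen on an aromatic ring. Among the compounds with values here, with no measured step between compounds that differ in one place, the expectation rests on this change alone. For compound 3 a lower number is expected, 40000 nM, with a range from 12000 nM to 120000 nM. The step that this estimate means, a 3.9-fold lower number from compound 1 to compound 3 (0.59 log units; beyond the scatter), is expected to be a drop lying beyond the scatter, though its size is uncertain.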

Compound 3, solubility: < 5000 nM
Compound 3: only a limit was reported; the forecaster's own chance of this, stated with the estimate: 10%; at least 8.0-fold (0.90 log units) between middle value and limit.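

The pair of compound 1 and compound 2 could say nothing about this position, since they differ in more than one place, but the step from pyrimidin-2-yl to 5-(trifluoromethyl)pyridin-2-yl on a nitrogen on an aromatic ring now gives a direct reading in this assay: an at least 31-fold lower number from compound 1 to compound 3 (1.49 log units; beyond the scatter). It shows that, with the rest of compound 1 held fixed, this one place alone can carry a large change in the read-out, far beyond the usual scatter. Compound 3 gives < 5000 nM, which is a limit of the assay and not a number, so the step shows a minimum size and the full size of the drop stays unknown: the limit of < 5000 nM in this assay, at which 1 of the 3 values shown sits.

The change swaps the ring and adds the trifluoromethyl group in a single step, so the compounds shown cannot divide the drop between the loss of a ring nitrogen and the gain of the trifluoromethyl group. They also leave open how this assay would respond if a carboxylic acid or an amine stood on the pyridine ring in place of the trifluoromethyl group.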